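Pyridyl variation at the ring nitrogen substituent

The source may report more compounds than this note shows. Statements on the series, on what has been measured and on what is new or still open speak of the compounds shown alone.

Compound 1 `CCCCNc1nc(N)nc2ccn(CCCc3ccccc3)c12` carries a phenethyl group on the saturated chain carbon bound to an aromatic nitrogen and in an assay on HEK293 cells for agonist activity at Toll-like receptor 8 (Homo sapiens), read by a luciferase reporter, with a stated time of 6 h (on this read-out higher numbers stand for an effect only at larger amounts of compound and lower numbers for an effect already at smaller amounts), compound 1 gives 3.78 uM. Compound 2 `CCCCNc1nc(N)nc2ccn(Cc3cccnc3)c12` has pyridin-3-yl at that place. In this assay compound 2 gives only a limit of the assay, > 25 uM, so no number is known for it; this is the situation described by the limit of > 25 uM in this assay, at which 1 of the 2 values shown sits. Going by the values given here, the one measured step, an at least 6.6-fold higher number from compound 1 to compound 2 (0.82 log units; beyond the scatter), goes from a number to the limit.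

Compound 3 `CCCCNc1nc(N)nc2ccn(Cc3cccc(C)n3)c12` differs from compound 2 in one place: 6-methylpyridin-2-yl in place of pyridin-3-yl on a saturated chain carbon bound to an aromatic nitrogen. Among the compounds with values here, the only step that bears on it shows that going from phenethyl to pyridin-3-yl ended at the limit, and nothing measured tells how one pyridyl differs from another here. Compound 3 is therefore expected to stay near the limit, with a step that the limit leaves unreadable from compound 2 to compound 3 not beyond the scatter. The estimate for compound 3 in this assay is 30 uM, from 8 uM to 100 uM.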

Compound 3, minimum effective concentration: > 25 uM
Compound 3 ended at the assay's limit (the forecaster's own chance of this, stated with the estimate: 65%); the middle value does not contradict the limit.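

In this assay compound 3 gives > 25 uM, which is a limit of the assay and not a number. Setting 6-methylpyridin-2-yl in place of phenethyl gives an at least 6.6-fold higher number from compound 1 to compound 3 (0.82 log units; beyond the scatter), so at this saturated chain carbon bound to an aromatic nitrogen the loss of a readable value is no longer confined to pyridin-3-yl, and the extra carbon of the entering group does not restore one. The step between compound 2 and compound 3 cannot be read, because both values are limits: the limit of > 25 uM in this assay, at which 2 of the 3 values shown sit.

Any order between compound 2 and compound 3 stays open. Also open, as far as these compounds go, is whether a number returns with a pyridin-3-yl group on a longer chain, or with a plain benzyl group in the same place.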